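A few compounds are considered here, and "the series" means these few. Any claim that something is new, unique, unknown or untested is made for them only; others in the source may bear on it.

In a functional assay on K562 cells (Homo sapiens) for antiproliferative activity, read by thymidine incorporation, with a stated time of 3 days (a higher number here means a weaker inhibitor, a lower number a stronger inhibitor), compound 1 `COc1ccc(-n2c(C)c(C)c(C)c2-c2cc(OC)c(OC)c(OC)c2)cc1O` gives 5400 nM. Compound 2 `COc1ccc(-c2c(C)c(C)c(C)n2-c2cc(OC)c(OC)c(OC)c2)cc1O` gives >= 10000 nM, which is a limit of the assay and not a number. Its true position is therefore open, and it offers only a weak anchor for the next step.

Compound 3 `COc1ccc(-c2c(C)c(C)c(C=O)n2-c2cc(OC)c(OC)c(OC)c2)cc1O` differs from compound 2 at a single place, with formyl in place of methyl on an aromatic carbon next to the ring nitrogen: formyl in place of methyl on an aromatic carbon.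

Going by the values given here, no measured pair covers this kind of change. A modest move towards stronger inhibition in this assay is expected, though a result within the scatter or another limit reading would be no surprise. The estimated change is an at least 1.6-fold lower number from compound 2 to compound 3 (0.22 log units; that floor lies within the scatter). For compound 3 the expected value is 6000 nM, with an estimated range of 1500 nM to 20000 nM.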

Compound 3, half-maximal inhibitory concentration: >= 10000 nM
Compound 3: no number, only a limit (the forecaster's own chance of this, stated with the estimate: 35%); at least 1.6-fold (0.22 log units) between middle value and limit.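

In this assay compound 3 gives >= 10000 nM, a limit of the assay and not a number. No step from compound 2 to compound 3 can be read, because both compounds stand at that limit: the limit of >= 10000 nM in this assay, at which 2 of the 3 values shown sit.

As far as these compounds go, whether formyl in place of methyl on an aromatic carbon changes inhibition at all remains open.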